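A few compounds are considered here, and "the series" means these few. Any claim that something is new, unique, unknown or untested is made for them only; others in the source may bear on it.

In a functional assay with Oryctolagus cuniculus as the target (a lower number here means a stronger inhibitor, a higher number a weaker inhibitor), the measured compounds read as follows:

Compound 1 `COc1ccc(-c2nc(/N=C(\N)n3ccnc3)sc2-c2ccc(OC)cc2)cc1` gives > 100 nM (a limit, not a number)
Compound 2 `COc1ccc(-c2nc(CNC(=O)c3cccnc3)sc2-c2ccc(OC)cc2)cc1` gives 25 nM (a number)
Compound 3 `COc1ccc(-c2nc(CNC(=O)C3=NNC(=O)CC3)sc2-c2ccc(OC)cc2)cc1` gives 55 nM (a number)

Of the two exact numbers, compound 3 holds the higher one, so it sits on the weaker side of compound 2. The entry for compound 1 is a limit, and it gives no exact place in this order.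

The next compound is compound 4 `COc1ccc(-c2nc(CNC(=O)NC(C)C)sc2-c2ccc(OC)cc2)cc1`, still unmeasured. The change from compound 3 is a group of 4 heavy atoms (3 carbon, 1 nitrogen; no ring) in place of a group of 7 heavy atoms (4 carbon, 2 nitrogen, 1 oxygen; one six-membered non-aromatic ring with 2 hetero atoms), on a carbonyl carbon, with isopropylamino entering on a carbonyl carbon whose other neighbours are: amide-type nitrogen.

Among the measured compounds shown here, two measured steps bear on this. The closer one is a 2.2-fold higher number from compound 2 to compound 3 (0.34 log units; beyond the scatter), also made on a carbonyl carbon, and it is modest. The other is an at least 4.0-fold lower number from compound 1 to compound 2 (0.60 log units; beyond the scatter), but it lies on an aromatic carbon and starts from a limit, so it says less here. For the measured compounds named here, no measured compound carries isopropylamino, which leaves the direction open.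

The expected step is a 1.1-fold higher number from compound 3 to compound 4 (0.04 log units; within the scatter), an estimate that stays within the scatter. For compound 4 the estimated value is 60 nM, with an expected range from 20 nM to 180 nM in this assay for now.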

Compound 4, half-maximal inhibitory concentration: 42 nM
Compound 4: middle estimate off by 1.4-fold (0.15 log units), on the high side; the range from low to high includes it.
By their numbers in this assay, from the lowest: compounds 2, 4 and 3 (each within the scatter of the next, the first and the last beyond it). At a limit, above all of these: compound 1.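

In this assay, the carbonyl carbon takes isopropylamino, a group with no ring, without a change that can be told from the scatter: a 1.3-fold lower number from compound 3 to compound 4 (0.12 log units; within the scatter), and a 1.7-fold higher number from compound 2 to compound 4 (0.23 log units; within the scatter). Until now this place had held only ring-bearing groups, so compound 4 shows that, among these three compounds, a ring on the carbonyl carbon is not needed for a value in this range, even though compound 2 and compound 3 lie beyond the scatter of each other. The remaining step, an at least 2.3-fold lower number from compound 1 to compound 4 (0.37 log units; beyond the scatter), is the only new one beyond the scatter, and it starts from a limit and not a number: the limit of > 100 nM in this assay, at which 1 of the 4 values shown sits.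

With compound 4 lying within the scatter of both compound 2 and compound 3, the compounds shown do not settle whether the group on the carbonyl carbon matters much in this assay, and three groups are too few to give a trend. They leave open how a longer chain such as n-butylamino, a cyclic amine such as morpholine, or a carboxylic acid would read at this carbonyl carbon.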